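Replacing naphthalen-1-yl on a sulfonamide: what to expect

The source may report more compounds than this note shows. Statements on the series, on what has been measured and on what is new or still open speak of the compounds shown alone.

Compound 1 `Cc1ccc(N(C)S(=O)(=O)C2CC3OC2C(c2ccc(NC(=O)CCCCCCC(=O)O)cc2)=C3c2ccc(O)cc2)cc1` gives > 100000 nM (a limit)
Compound 2 `CN(c1cccc2ccccc12)S(=O)(=O)C1CC2OC1C(c1ccc(NC(=O)CCCCCCC(=O)O)cc1)=C2c1ccc(O)cc1` gives 70900 nM

For the measured compounds named here, in a functional assay on DU-145 cells (Homo sapiens) for antiproliferative activity, read by MTT assay, with a stated time of 72 h (a higher number here means a weaker inhibitor, a lower number a stronger inhibitor), compound 2 gives 70900 nM as the only true number so far, a high reading that means weak inhibition. Compound 1 gives only a limit (> 100000 nM) and no number.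

Compound 3 `CCN(c1cccc(C)c1)S(=O)(=O)C1CC2OC1C(c1ccc(NC(=O)CCCCCCC(=O)O)cc1)=C2c1ccc(O)cc1` carries ethyl(3-methylphenyl)amino in place of the methyl(naphthalen-1-yl)amino of compound 2 on a sulfonyl sulfur (ethyl(3-methylphenyl)amino in place of methyl(naphthalen-1-yl)amino on a sulfonyl sulfur) and is otherwise the same.

Going by the values given here, one measured step bears on this change: an at least 1.4-fold lower number from compound 1 to compound 2 (0.14 log units; that floor lies within the scatter) came with naphthalen-1-yl in place of 4-methylphenyl on a sulfonamide nitrogen. Starting from compound 2 at 70900 nM and with only that step as a guide, no change beyond the scatter is expected in this assay for compound 3. A reading that is only a limit remains quite possible for compound 3. The estimate thus means a 1.1-fold higher number from compound 2 to compound 3 (0.05 log units; within the scatter) as the expected step. The estimate for compound 3 is 80000 nM with 40000 nM to 160000 nM as its expected range.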

Compound 3, half-maximal inhibitory concentration: 65600 nM
Beside the measured number, compound 3's estimate is 1.2-fold (0.09 log units) above it; measured number inside the range.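

In this assay, ethyl(3-methylphenyl)amino on the sulfonyl sulfur, with one six-membered aromatic ring, takes the place of methyl(naphthalen-1-yl)amino, with two, and the outcome is a 1.1-fold lower number from compound 2 to compound 3 (0.03 log units; within the scatter). At this position, then, the two groups cannot be told apart, and the second aromatic ring of the naphthalen-1-yl group brings no measurable gain at this weak level of activity. The other comparison, an at least 1.5-fold lower number from compound 1 to compound 3 (0.18 log units; that floor lies within the scatter), gives only a floor, so it sets no order between the two compounds, and compound 1 remains a limit and not a number: the limit of > 100000 nM in this assay, at which 1 of the 3 values shown sits.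

All the groups shown on the sulfonyl sulfur are amino groups that carry an aromatic ring, so it remains open whether a ring amine without one, such as piperidine or morpholine, or a small dimethylamino group would move the reading beyond the scatter. Going by these compounds, it also remains open whether any change at this position matters more than a change elsewhere, such as a hydroxamic acid in place of the carboxylic acid at the end of the shared chain.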